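From Methyl to Pentyl on Compound 2

The compounds below may be only part of what the source reports. "The series", "measured", "known", "first", "only" and "open" are said of these compounds alone.

In a functional assay on MDA-MB-231 cells (Homo sapiens) for antiproliferative activity, with a stated time of 4 days (a higher number here means a weaker inhibitor, a lower number a stronger inhibitor), compound 2 (`COc1ccc(-c2[nH]c3ccc(C)cc3c2C=O)cc1`) stands at 86 nM as the weakest of three measured inhibitors, against compound 1 (`COc1ccc(-c2[nH]c3cc(Cl)c(C)cc3c2C=O)cc1`) at 26 nM and compound 3 (`COc1ccc(-c2[nH]c3ccc(C(C)C)cc3c2C=O)cc1`) at 29 nM on the same scale. Compound 4 (`CCCCCc1ccc2[nH]c(-c3ccc(OC)cc3)c(C=O)c2c1`) differs from compound 2 by butyl in place of hydrogen on a saturated chain carbon bound to an aromatic carbon as butyl in place of hydrogen on a saturated chain carbon bound to an aromatic carbon, so that methyl becomes pentyl. Among the measured compounds shown here, the closest precedent is isopropyl in place of methyl, which gave a 3.0-fold lower number from compound 2 to compound 3 (0.47 log units; beyond the scatter) and also replaces that methyl. The other measured step, a 3.3-fold higher number from compound 1 to compound 2 (0.52 log units; beyond the scatter) with hydrogen in place of chloro on an aromatic carbon, bears on this change only weakly. No straight chain longer than methyl has been measured, so the isopropyl step is only a rough guide. On that guide, an estimated 2.2-fold lower number from compound 2 to compound 4 (0.33 log units; beyond the scatter) is expected, a modest move toward a lower number. In this assay compound 4 is estimated at 40 nM (expected range 13 nM to 130 nM).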

Compound 4, half-maximal inhibitory concentration: 5.5 nM
The estimate for compound 4 lay 7.3-fold (0.86 log units) above the measured number; the measured number lies below the stated range.
By their numbers in this assay, from the lowest: compound 4; then compounds 1 and 3 (each within the scatter of the next); then compound 2.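

In this assay, replacing methyl with pentyl gave a 16-fold lower number from compound 2 to compound 4 (1.19 log units; beyond the scatter), a large step and the biggest yet seen at this position, where isopropyl had brought only a modest gain. Pentyl also goes clearly beyond isopropyl, with a 5.3-fold lower number from compound 3 to compound 4 (0.72 log units; beyond the scatter), so the branched group did not mark the limit of what this position accepts. Across these three compounds, the number falls at each step from methyl through isopropyl to pentyl, and none of the three goes against that order.

No measurement at hand gives a reason for this drop. Still open, on these data alone, is whether a longer chain such as heptyl would lower the number further, whether a straight propyl chain would fit the same trend, and whether a chain carrying an amine would keep the gain.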